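The source may report more compounds than this note shows. Statements on the series, on what has been measured and on what is new or still open speak of the compounds shown alone.

Measured in an ADME assay on cells (Hepatocyte, Homo sapiens) for metabolic stability, with a stated time of 30 min; a lower number here means that less of the compound is left, a higher number that more of the compound is left:
Compound 1 `NC1CCC(CN2CCN(c3cc(=O)c4cc(C(F)(F)F)cc([N+](=O)[O-])c4s3)CC2)CC1`: 83.6%
Compound 2 `CC(=O)NC1CCC(CN2CCN(c3cc(=O)c4cc(C(F)(F)F)cc([N+](=O)[O-])c4s3)CC2)CC1`: 86.8%

Going by the values given here, compound 2 stands at 86.8% in this assay, within the scatter of compound 1, the only other measured compound. The change to compound 3 `O=C(OC1CCC(CN2CCN(c3cc(=O)c4cc(C(F)(F)F)cc([N+](=O)[O-])c4s3)CC2)CC1)c1cccs1` is ((thiophen-2-yl)carbonyl)oxy in place of acetamido on a saturated ring carbon. Among the compounds with values here, only one measured step bears on this, and only loosely: a number 3.2 percentage points higher from compound 1 to compound 2 (within the scatter), with acetyl in place of hydrogen on an amine nitrogen. Within the data shown here, that nitrogen stays on the ring carbon in both compounds, whereas here it leaves, and no measured compound shows what happens without it. A moderate fall in this assay is therefore expected, held with wide uncertainty. The expected change is a number 12.8 percentage points lower from compound 2 to compound 3 (beyond the scatter). Compound 3 is estimated at 74%, with an expected range of 50% to 92%.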

Compound 3, percent of the compound remaining: 2.2%
Compound 3: the middle estimate sits 71.8 percentage points above what was measured; measured number outside the range, below it.
By their numbers in this assay, from the lowest: compound 3; then compounds 1 and 2 (each within the scatter of the next).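

The two nitrogen groups on the saturated ring carbon gave no separation in this assay, but this position is far from indifferent to what it carries. With ((thiophen-2-yl)carbonyl)oxy in place of acetamido, the result is a number 84.6 percentage points lower from compound 2 to compound 3 (beyond the scatter) and with the same group in place of amino, it is a number 81.4 percentage points lower from compound 1 to compound 3 (beyond the scatter) so both nitrogen compounds stand apart from the new ester by a large margin. No available evidence explains this fall.

The change brings in the oxygen link and the thiophene ring together, so the compounds shown leave open which of them goes with the fall. A (thiophen-2-yl)carbonylamino group or an acetyloxy group on the same ring carbon would separate the two, and a plain hydroxyl group would show the oxygen without any acyl group.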